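A few compounds are considered here, and "the series" means these few. Any claim that something is new, unique, unknown or untested is made for them only; others in the source may bear on it.

Three compounds share one core, and all three have been tested in an ADME assay on HCT-116 cells (Homo sapiens) for cytotoxicity, read by MTT assay; on this read-out higher numbers stand for lower toxicity in this test and lower numbers for higher toxicity in this test. Compound 1 `Cc1nc(-c2cccnc2)sc1-c1nnc(-c2ccncc2)o1` gives > 100 ug/mL in this assay, which is a limit of the assay rather than a number. Compound 2 `COc1ccccc1-c1nnc(-c2sc(-c3cccnc3)nc2C)o1` likewise gives > 100 ug/mL, again a limit. Compound 3 `Cc1ccccc1-c1nnc(-c2sc(-c3cccnc3)nc2C)o1` gives > 100 ug/mL in this assay, also a limit. Within the data shown here, because of the limit of > 100 ug/mL in this assay, at which 3 of the 3 values shown sit, no compound among the three stands apart from the others, and the measured steps between them — a step that the two limits leave unreadable from compound 1 to compound 2, a step that the two limits leave unreadable from compound 1 to compound 3 and a step that the two limits leave unreadable from compound 2 to compound 3 — cannot be read.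

Compound 4 `Cc1nc(-c2cccnc2)sc1-c1nnc(-c2ccc(Cl)cc2)o1` is the next compound, and it differs from compound 3 in a single place: 4-chlorophenyl in place of 2-methylphenyl on an aromatic carbon. The steps measured so far bear on the same position, since the 2-methoxyphenyl, 2-methylphenyl and pyridin-4-yl groups were each tried there, yet none of them gave a readable size. On that evidence no step beyond the scatter is expected, and the step of a number no higher from compound 3 to compound 4 (the limit leaves the size open) is estimated to stay within it. Compound 4 is therefore expected to give 100 ug/mL in this assay, within a range from 50 ug/mL to 200 ug/mL, and most likely to be reported only as a limit.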

Compound 4, half-maximal cytotoxic concentration: > 100 ug/mL
Compound 4 gave a limit, no number (the forecaster's own chance of this, stated with the estimate: 80%); the middle value sits exactly at the limit.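

Compound 4 gives > 100 ug/mL in this assay and this is a limit, not a number. Its steps from compound 1, compound 2 and compound 3 therefore cannot be read: the limit of > 100 ug/mL in this assay, at which 4 of the 4 values shown sit. The compounds shown leave open how toxic any of them is to these cells, and whether changing the group on the shared core alters that at all.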